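Second methoxy on the methoxyphenyl ring of compound 3

The source may hold more compounds than are shown below. What is called first, only, known or untested is meant among the compounds shown, and "the series" means these compounds.

Working notes on the series. The three measured compounds share one core and differ only on a six-membered aromatic ring of carbon only. In a functional assay on the whole organism (strain Wistar) for inhibition, with Rattus norvegicus as the target, read by paw edema, with a stated time of 30 min, at a dose of 10 mg/kg by the intraperitoneal route (on this read-out higher numbers stand for more inhibition at the one dose given (going by the name of the read-out) and lower numbers for less inhibition), compound 1 `O=C(N/N=C/c1ccc(Cl)cc1)c1cccnc1Nc1cccc(C(F)(F)F)c1` gives 52.4%, compound 2 `O=C(N/N=C/c1ccc(O)cc1)c1cccnc1Nc1cccc(C(F)(F)F)c1` gives 59.3% and compound 3 `COc1ccc(/C=N/NC(=O)c2cccnc2Nc2cccc(C(F)(F)F)c2)cc1` gives 50.4%. Every gap among them lies within the scatter: a number 6.9 percentage points higher from compound 1 to compound 2 (within the scatter), a number 2 percentage points lower from compound 1 to compound 3 (within the scatter) and a number 8.9 percentage points lower from compound 2 to compound 3 (within the scatter). Compound 3 carries the lowest of the three numbers shown, yet its separation from each of the others is within the scatter, so no ranking can be read from these figures.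

Compound 4 `COc1ccc(/C=N/NC(=O)c2cccnc2Nc2cccc(C(F)(F)F)c2)cc1OC` differs from compound 3 in one place: methoxy in place of hydrogen on an aromatic carbon. The measured steps that touched the same ring are a number 2 percentage points lower from compound 1 to compound 3 (within the scatter) and a number 8.9 percentage points lower from compound 2 to compound 3 (within the scatter), both within the scatter. Within the data shown here, no measured pair takes this ring from one substituent to two, so the series speaks only to changes of a single substituent, none of which moved the read-out beyond the scatter. The expectation for compound 4 in this assay is therefore a number close to that of compound 3, with no step beyond the scatter. The expected step reads a number 0.6 percentage points higher from compound 3 to compound 4 (within the scatter). Compound 4 is estimated to give 51%, with a range from 40% to 62%.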

Compound 4, a percentage reported as inhibition, in the whole organism at one dose (the size of the read-out at that dose, not a potency): 60.1%
Estimate against measurement, compound 4: 9.1 percentage points below; the measured number falls inside the stated range.
By their numbers in this assay, from the lowest: compounds 3, 1, 2 and 4 (each within the scatter of the next).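

In this assay, among these compounds, the change from 4-methoxyphenyl to 3,4-dimethoxyphenyl, which places methoxy on an aromatic carbon ortho to a methoxy group, gives a number 9.7 percentage points higher from compound 3 to compound 4 (within the scatter) and is the only measured step that takes this ring from one substituent to two. The 3,4-dimethoxyphenyl ring also stays within the scatter of the other two rings, with a number 0.8 percentage points higher from compound 2 to compound 4 (within the scatter) and a number 7.7 percentage points higher from compound 1 to compound 4 (within the scatter), so adding the second substituent does not separate compound 4 from any compound shown in this read-out. Nothing shown gives a measured basis for interpreting these numbers.

Going by these compounds, whether a different group on this same aromatic carbon, such as an amine, a carboxylic acid or a longer chain such as ethoxy, would give a step beyond the scatter remains open. On these data alone, it also remains open whether the four compounds would separate at other doses or times, since the values shown describe the size of the read-out at one dose and give no potency.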